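A Side Chain Exchange on Compound 2

This account rests on a few compounds, and the source may have more. Where it says the series, first, only, none or still open, it means among the compounds named here.

Of the compounds shown here, three built on one shared core have been read out in an in vitro ADME assay on microsomes from liver (Homo sapiens) for metabolic stability (on this read-out higher numbers stand for fast clearance and lower numbers for slow clearance), so far. Compound 1 (`Cc1cc(Nc2ccc(C(F)(F)F)cc2)n2nc(CCO)nc2n1`) gives < 5 mL.min-1.g-1 here, which is a limit of the assay and not a number. Compound 2 (`COCCc1nc2nc(C)cc(Nc3ccc(S(F)(F)(F)(F)F)cc3)n2n1`) gives 11.5 mL.min-1.g-1 and compound 3 (`CCc1nc2nc(C)cc(Nc3cccc(Cl)c3)n2n1`) gives 78.3 mL.min-1.g-1 in the same measurement, so compound 2 holds the lower of the two actual numbers, with a gap to compound 3 that lies beyond the scatter.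

Compound 4 (`Cc1cc(Nc2ccc(S(F)(F)(F)(F)F)cc2)n2nc(C(F)(F)F)nc2n1`) has not yet been measured. It carries trifluoromethyl in place of 2-methoxyethyl on an aromatic carbon of a five-membered aromatic ring with 3 nitrogen, part of a fused or bridged system of two rings (trifluoromethyl in place of 2-methoxyethyl on an aromatic carbon). Within the data shown here, no measured pair of compounds shows this exchange on its own, so the expectation is cautious. Compound 2 at 11.5 mL.min-1.g-1 already stands at the slow end of the numbers. The expected change is an estimated 1.6-fold lower number from compound 2 to compound 4 (0.22 log units; within the scatter) toward slower clearance, a step within the scatter. For compound 4 the estimated value is 7 mL.min-1.g-1 with an expected range of 4 mL.min-1.g-1 to 16 mL.min-1.g-1 in this read-out.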

Compound 4, intrinsic clearance in microsomes: < 5 mL.min-1.g-1
Compound 4 was reported as a limit; the forecaster's own chance of this, stated with the estimate: 40%; middle value at least 1.4-fold (0.14 log units) from the limit.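

The exchange of 2-methoxyethyl for trifluoromethyl on an aromatic carbon of the five-membered aromatic ring with 3 nitrogen, between two ring nitrogen atoms, gives in this assay an at least 2.3-fold lower number from compound 2 to compound 4 (0.36 log units; beyond the scatter), the only step among the compounds shown that isolates a change in one place, and it shows that this position can move the read-out by more than the usual scatter. Compound 4 gives < 5 mL.min-1.g-1, which is a limit of the assay and not a number. The step therefore fixes only the smallest size the change can have, and its full size cannot be read from this pair: the limit of < 5 mL.min-1.g-1 in this assay, at which 2 of the 4 values shown sit.

The compounds shown leave open how an amine, a carboxylic acid or a longer chain on this same aromatic carbon would read out in this assay, and whether the exchange to trifluoromethyl would give a step of similar size on another compound with the shared core. They also give no order between compound 1 and compound 4, which differ in more than one place and both stand at a limit.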